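The compounds below may be only part of what the source reports. "The series", "measured", "known", "first", "only" and "open" are said of these compounds alone.

Compound 1 `Cn1cc(C2CC(c3ccccc3)=NN2C(=O)c2cccnc2)c2ccccc21`: > 10000 nM
Compound 2 `COc1ccc2c(c1)c(C1CC(c3ccccc3)=NN1C(=O)c1cccnc1)cn2C`: > 10000 nM
Compound 3 `COc1cccc(C2=NN(C(=O)c3cccnc3)C(c3cn(C)c4ccc(OC)cc34)C2)c1`: not yet measured

Both values are limits of a functional assay on A549 cells (Homo sapiens) for inhibition, read by MTT assay, with a stated time of 48 h (a lower number here means a stronger inhibitor of growth, a higher number a weaker inhibitor of growth), not numbers. Compound 2 stands at the limit of > 10000 nM in this assay, at which 2 of the 2 values shown sit. Compound 3 differs from compound 2 by methoxy in place of hydrogen on an aromatic carbon, turning phenyl to 3-methoxyphenyl. Among the measured compounds shown here, the only measured step of this kind, methoxy in place of hydrogen on an aromatic carbon, is a step that the two limits leave unreadable from compound 1 to compound 2, so it gives no size or direction to carry over. No change beyond the scatter is therefore expected. The expected step is a step that the limit leaves unreadable from compound 2 to compound 3. For compound 3 the estimated value is 12000 nM, with an expected range of 4000 nM to 30000 nM.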

Compound 3, concentration for 50% growth inhibition: 1020 nM
For compound 3 the middle estimate is 12-fold (1.07 log units) above the measured one, and the stated range ends above it.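

In this assay, phenyl to 3-methoxyphenyl gives the first readable step of this kind in the series: an at least 9.8-fold lower number from compound 2 to compound 3 (0.99 log units; beyond the scatter). The earlier methoxy step, at another place on the core, cannot be read, so this aromatic carbon is the only place shown where adding methoxy moves the result out of the limit. The size of the step is only a bound, with compound 2 at a limit and not a number: the limit of > 10000 nM in this assay, at which 2 of the 3 values shown sit.

On these data alone, whether a hydroxyl, an amine or a longer alkoxy chain would serve at this carbon remains open. Also open, as far as these compounds go, is whether 3-methoxyphenyl gives a similar step on the core of compound 1.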